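The source may report more compounds than this note shows. Statements on the series, on what has been measured and on what is new or still open speak of the compounds shown alone.

Measured so far:
- compound 1 `COc1cc2c(cc1OC)CN(c1cccnc1)CC2`: 39.5 10^-6 cm/s
- compound 2 `COc1cc2c(cc1OC)CN(c1cc(C(F)(F)F)cc(C(F)(F)F)c1)CC2`: < 0.1 10^-6 cm/s (a limit)

Among the compounds with values here, in an ADME assay on Caco-2 cells (Homo sapiens) for permeability, read by LC-MS, with a stated time of 2 h, tested at 25 uM (a lower number here means that the compound crosses the layer more slowly, a higher number that the compound crosses the layer faster), compound 1 gives 39.5 10^-6 cm/s, the only actual number so far. Compound 2 gives < 0.1 10^-6 cm/s, which is a limit and not a number.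

Compound 3 `COc1cc2c(cc1OC)CN(c1ccccn1)CC2` has not yet been measured. Its difference from compound 1 is pyridin-2-yl in place of pyridin-3-yl on an amine nitrogen in a ring, the same atoms joined differently. Within the data shown here, no measured step between close analogues is available to size this change. In this assay, no change beyond the usual scatter is expected in either direction, an expectation resting on compound 1 at 39.5 10^-6 cm/s and on the unchanged counts. The expected size is a 1.0-fold higher number from compound 1 to compound 3 (0.01 log units; within the scatter). For compound 3 the estimated value is 40 10^-6 cm/s, with an expected range of 18 10^-6 cm/s to 75 10^-6 cm/s.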

Compound 3, apparent permeability in the Caco-2 assay: 38.8 10^-6 cm/s
Compound 3: the middle estimate sits 1.0-fold (0.01 log units) above what was measured; low and high end bracket the measured number.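

Within the data shown here, with pyridin-2-yl in place of pyridin-3-yl on an amine nitrogen in a ring, the Caco-2 assay gives the first readable step: a 1.0-fold lower number from compound 1 to compound 3 (0.01 log units; within the scatter). In the Caco-2 assay compound 1 gives 39.5 10^-6 cm/s and compound 3 gives 38.8 10^-6 cm/s. At this position, the two pyridine attachments cannot be told apart in that assay, although their atoms are joined differently. In a physicochemical assay for lipophilicity, at pH 7.4 (a higher number here means a more lipophilic compound, a lower number a more polar compound), compound 1 gives 3.7 and compound 3 gives 3.7. In the physicochemical assay the same pair shows no change at the digits printed from compound 1 to compound 3 (within the scatter), and nothing shown gives a reason for either result.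

As far as these compounds go, in the Caco-2 assay, compound 2 gives a limit and not a number: the limit of < 0.1 10^-6 cm/s in the Caco-2 assay, at which 1 of the 3 values shown sits. It remains open whether pyridin-4-yl or an unsubstituted phenyl on the same amine nitrogen would stay with compound 1 or fall towards that limit, and what replacing the methoxy groups of the shared core would do.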